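Amide changes on the ring nitrogen of the shared core

This account rests on a few compounds, and the source may have more. Where it says the series, first, only, none or still open, it means among the compounds named here.

Compound 2 `CC(C)NC(=O)CN1CCN(c2ccc(OCC3CCN(C(=O)OC(C)C)CC3)cn2)CC1` is the reference point for this step. In a functional assay on CHO-K1 cells for agonist activity at Glucose-dependent insulinotropic receptor (Homo sapiens), read by a luciferase reporter, with a stated time of 5 h (a lower number here means that less compound is needed, a higher number that more compound is needed for the effect), compound 2 gives > 10000 nM, which is a limit of the assay and not a number. Compound 1 `CC(C)OC(=O)N1CCC(COc2ccc(N3CCN(C(=O)N(C)C)CC3)nc2)CC1` differs from compound 2 only at the amine nitrogen in a ring. In this assay compound 1 gives > 10000 nM, which is likewise a limit. The step that the two limits leave unreadable from compound 1 to compound 2 is all that the two values allow. Everything shown so far sits at the limit of > 10000 nM in this assay, at which 2 of the 2 values shown sit.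

Compound 3 `CC(=O)N1CCN(c2ccc(OCC3CCN(C(=O)OC(C)C)CC3)cn2)CC1` has not been measured. It differs from compound 2 by acetyl in place of (isopropylcarbamoyl)methyl on an amine nitrogen in a ring. Within the data shown here, the only measured step at this position, from compound 1 to compound 2, cannot be sized, so no measured step gives a reading for the change to an acetyl group. Compound 2 sits at a limit in this assay, and the step that the limit leaves unreadable from compound 2 to compound 3 is expected to leave that situation unchanged. Compound 3 is estimated at 15000 nM in this assay, with a range from 3000 nM to 60000 nM, and the most probable outcome is once more only a limit rather than a number.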

Compound 3, half-maximal effective concentration: > 10000 nM
Compound 3: no number, only a limit; the forecaster's own chance of this, stated with the estimate: 85%; the middle value is on the limit's open side.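

In this assay compound 3 gives > 10000 nM, a limit of the assay and not a number. No step among compound 1, compound 2 and compound 3 can be read, as all three values are limits: the limit of > 10000 nM in this assay, at which 3 of the 3 values shown sit.

The compounds shown leave open whether any group on the amine nitrogen in a ring of the shared core gives a readable value in this assay.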